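Methoxy in place of hydrogen on the aryl ring

The compounds below may be only part of what the source reports. "The series", "measured", "known", "first", "only" and "open" are said of these compounds alone.

Compound 3 `Cc1ccc(C(=O)CCc2nnc(-c3ccccc3)o2)c(C)c1` stands second highest of the three measured compounds in a functional assay on the whole organism (strain Wistar) for inhibition, with Rattus norvegicus as the target, with stated times of 30 min and 2 h, at a dose of 20 mg/kg by the oral route (a higher number here means more inhibition at the dose given (going by the name of the read-out), a lower number less inhibition), with 36%. Its nearest neighbour is compound 1 `Cc1ccc(C(=O)CCc2nnc(-c3ccccc3)o2)cc1`, which gives 33.3%; the difference a number 2.7 percentage points higher from compound 1 to compound 3 (within the scatter) lies within the scatter. Furthest away is compound 2 `COc1ccc(-c2nnc(CCC(=O)c3ccc(C)cc3)o2)cc1OC`, which gives 53.3%, a number beyond the scatter from compound 3.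

Compound 4 `COc1ccc(-c2nnc(CCC(=O)c3ccc(C)cc3C)o2)cc1` differs from compound 3 in one place: methoxy in place of hydrogen on an aromatic carbon. Among the measured compounds shown here, the only measured step, the one from compound 1 to compound 3, concerns a methyl and does not bear directly on this change. The pair of compound 1 and compound 2 is not a single-place step, but compound 2, which carries two methoxy groups, shows the higher number of the two. The account therefore expects a modest upward step a number 9 percentage points higher from compound 3 to compound 4 (within the scatter) in this assay, though one methoxy may give less than two. Compound 4 is estimated at 45%, with a range from 30% to 60%.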

Compound 4, a percentage reported as inhibition, in the whole organism at one dose (the size of the read-out at that dose, not a potency): 62.7%
Compound 4: middle estimate off by 17.7 percentage points, on the low side; measured number above the stated range.
By their numbers in this assay, from the lowest: compounds 1 and 3 (each within the scatter of the next); then compounds 2 and 4 (each within the scatter of the next).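

In this assay, the phenyl to 4-methoxyphenyl change gives a number 26.7 percentage points higher from compound 3 to compound 4 (beyond the scatter), which shows that this position, para to a large group on a six-membered aromatic ring of carbon only, can carry a single methoxy with a clear gain in inhibition at the dose given. The earlier step with a methyl, a number 2.7 percentage points higher from compound 1 to compound 3 (within the scatter), had shown no change that could be told from the scatter, so this is the first single-place change in the series to move the read-out beyond it. Nothing measured here accounts for the size of this step.

The compounds shown leave open whether an amine, a hydroxyl or a chlorine at the same place would match methoxy. They also leave open whether a longer chain such as ethoxy would keep the gain.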